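Compound 2 and the chloro step

The source may report more compounds than this note shows. Statements on the series, on what has been measured and on what is new or still open speak of the compounds shown alone.

Measured so far in a functional assay on the whole organism with Mus musculus as the target (a lower number here means that less compound is needed, a higher number that more compound is needed for the effect), are:
compound 1 `COc1cc2c(cc1OC)C(c1ccc(Br)cc1)=NN=C(S)C2` with 52.1 umol/kg as its value
compound 2 `COc1cc2c(cc1OC)C(c1ccc(N)cc1)=NNC(=O)C2` with 15 umol/kg as its value
compound 3 `COc1cc2c(cc1OC)C(c1ccccc1)=NN(C)C(=S)C2` with 30.6 umol/kg as its value

Compound 2 has the lowest number of the three, and the gaps to both others lie beyond the scatter. The step to compound 4 `COc1cc2c(cc1OC)C(c1ccc(Cl)cc1)=NNC(=O)C2` puts chloro in place of amino on an aromatic carbon, para to a large group, chloro in place of amino on an aromatic carbon and leaves the rest of compound 2 unchanged. For the measured compounds named here, no measured pair shows this change directly. The nearest guide is compound 1, a bromo compound that differs elsewhere too, at 52.1 umol/kg in this assay for its dose. A moderate upward a 2.3-fold higher number from compound 2 to compound 4 (0.37 log units; beyond the scatter) is therefore expected, with much uncertainty. Compound 4 is estimated at 35 umol/kg with 14 umol/kg to 90 umol/kg as the expected range.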

Compound 4, dose for half-maximal effect: 102 umol/kg
For compound 4 the middle estimate is 2.9-fold (0.46 log units) below the measured one; measured number outside the range, above it.
By their numbers in this assay, from the lowest: compound 2; then compounds 3, 1 and 4 (each within the scatter of the next, the first and the last beyond it).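

Chloro in place of amino at this position gives a 6.8-fold higher number from compound 2 to compound 4 (0.83 log units; beyond the scatter), the first reading among these compounds of a single change at one place. On the shared core, the 4-aminophenyl compound therefore needs clearly less compound for the effect than the 4-chlorophenyl compound. The data give no reason for this step.

The compounds shown leave open whether the rise is specific to chloro or would also follow from other replacements of amino. Compounds carrying a dimethylamino, hydroxyl or methoxy group at this position on the same core would help to separate these possibilities.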